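Trimethoxyphenyl in place of naphthalenyl on a pyrazoline core

The compounds below may be only part of what the source reports. "The series", "measured", "known", "first", "only" and "open" are said of these compounds alone.

Compound 1 `COc1cc(C2CC(c3cccc4ccccc34)=NN2C(C)=O)ccc1OCc1cn(Cc2ccc([N+](=O)[O-])cc2)nn1` is the strongest of the three measured compounds in a functional assay on THP-1 cells (Homo sapiens) for inhibition, read by sulforhodamine B assay, tested at 100 uM (a higher number here means more inhibition of growth at the concentration tested, a lower number less inhibition of growth), where compound 1 gives 79%. Compound 3 `COc1cc(C2CC(c3ccc(OCc4cn(Cc5ccc([N+](=O)[O-])cc5)nn4)cc3)=NN2C(C)=O)ccc1Oc1cn(Cc2ccc([N+](=O)[O-])cc2)nn1` comes nearest to it, yet in this assay compound 3 gives only 15%, a gap beyond the usual scatter. Compound 2 `COc1ccc(C2CC(c3ccc(OCc4cn(Cc5ccc([N+](=O)[O-])cc5)nn4)cc3)=NN2C(C)=O)cc1OC` lies furthest away; in this assay compound 2 gives 9%, again well beyond the scatter. Both of the weaker compounds carry a large group on the carbon with a double bond to nitrogen, whereas compound 1 carries naphthalen-1-yl there.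

Compound 4 `COc1cc(C2CC(c3cc(OC)c(OC)c(OC)c3)=NN2C(C)=O)ccc1OCc1cn(Cc2ccc([N+](=O)[O-])cc2)nn1` is the next compound to be considered. It differs from compound 1 in one place: 3,4,5-trimethoxyphenyl in place of naphthalen-1-yl on a carbon with a double bond to nitrogen. Among the compounds with values here, no measured pair shows this exact exchange, so the size of the step is open. Given that compound 3 gives 15% with a different group at the same place, some loss relative to compound 1 is expected, though a smaller one than for the measured weaker compounds. For compound 4 the step of a number 24 percentage points lower from compound 1 to compound 4 (beyond the scatter) is the expected change. Compound 4 is estimated at 55%, within a range from 25% to 85%.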

Compound 4, percent growth inhibition at one concentration: 43%
For compound 4 the middle estimate is 12 percentage points above the measured one; measured number inside the range.
By their numbers in this assay, from the lowest: compounds 2 and 3 (each within the scatter of the next); then compound 4; then compound 1.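

In this assay, within the data shown here, 3,4,5-trimethoxyphenyl in place of naphthalen-1-yl on the carbon with a double bond to nitrogen gives a number 36 percentage points lower from compound 1 to compound 4 (beyond the scatter), the first single-change pair to show directly that this position bears on growth inhibition. The exchange replaces two six-membered aromatic rings of carbon only with one such ring and brings in 3 hydrogen-bond acceptors, yet compound 4 still gives 43% in this assay, so the loss at this position is large but not complete. Nothing measured here explains the fall, and this one pair cannot separate the loss of the second ring from the entry of the methoxy groups.

As far as these compounds go, it remains open how an unsubstituted phenyl ring would compare at this position. Also open, from the compounds shown here alone, is how a phenyl ring carrying an amine or a carboxylic acid would fare there.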